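A few compounds are considered here, and "the series" means these few. Any claim that something is new, unique, unknown or untested is made for them only; others in the source may bear on it.

Measured in a functional assay on BV-2 cells (Mus musculus) for inhibition, read by ELISA, with a stated time of 16 h; on this read-out higher numbers stand for weaker inhibition and lower numbers for stronger inhibition:

Compound 1 `Cc1cc(-c2cccc(F)c2)nnc1N1CCN(c2ncccn2)CC1` gives 33500 nM.
Compound 2 `Cc1cc(-c2ccsc2)nnc1N1CCN(c2ncccn2)CC1` gives 2400 nM.

Compound 2 stands at the lowest of the two numbers in this assay; its nearest neighbour is compound 1, and the step between them, a 14-fold lower number from compound 1 to compound 2 (1.14 log units; beyond the scatter), lies well beyond the scatter.

Compound 3 `Cc1cc(-c2ccc3[nH]ccc3c2)nnc1N1CCN(c2ncccn2)CC1` differs from compound 2 in one place: 1H-indol-5-yl in place of thiophen-3-yl on an aromatic carbon. Among the compounds with values here, the only measured step that bears on this position is a 14-fold lower number from compound 1 to compound 2 (1.14 log units; beyond the scatter), which shows that the aromatic group on this carbon can shift the read-out in this assay by a large amount. That step, however, compares a six-membered ring with a five-membered one, and nothing measured shows what a bicyclic group such as 1H-indol-5-yl does there. Compound 3 is therefore expected to move only a little from compound 2, with a wide margin in either direction: the estimated step is a 1.5-fold higher number from compound 2 to compound 3 (0.16 log units; within the scatter). For compound 3 the estimated value in this assay is 3500 nM, with a range from 800 nM to 15000 nM.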

Compound 3, half-maximal inhibitory concentration: 85100 nM
Beside the measured number, compound 3's estimate is 24-fold (1.39 log units) below it, and the stated range ends below it.
By their numbers in this assay, from the lowest: compound 2; then compound 1; then compound 3.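

In this assay, the aromatic group on this carbon again moves the read-out by a large amount: 1H-indol-5-yl in place of thiophen-3-yl gives a 35-fold higher number from compound 2 to compound 3 (1.55 log units; beyond the scatter), so enlarging the group to a fused ring pair does not preserve the low number of compound 2. Set against the 3-fluorophenyl group, the same 1H-indol-5-yl group gives a 2.5-fold higher number from compound 1 to compound 3 (0.40 log units; beyond the scatter), which makes compound 3 the weakest of the three and leaves thiophen-3-yl, the only one of these groups without a six-membered aromatic ring, as the one with the lowest number. Nothing available here accounts for why the read-out moves in this way.

As far as these compounds go, it remains open whether the low number of compound 2 belongs to a single five-membered aromatic ring as such or to its sulfur, a question that a furan-3-yl or a 1H-pyrazol-4-yl group on this carbon would address. Also open, from the compounds shown here alone, is how much of the high number of compound 3 goes with the indole hydrogen on nitrogen, which a benzothiophen-5-yl group, with sulfur in that ring, would help to separate.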